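Removing an Acetyl Group: Effect on Tolerated Concentration

This account rests on a few compounds, and the source may have more. Where it says the series, first, only, none or still open, it means among the compounds named here.

Compound 1 `CC(=O)Nc1ccc2oc(-c3cccc(F)c3)cc(=O)c2c1` gives 240000 nM
Compound 2 `Nc1ccc2oc(-c3cccc(F)c3)cc(=O)c2c1` gives 269000 nM
Compound 3 `COc1c(-c2ccccc2)oc2ccc(NC(C)=O)cc2c1=O` gives 200000 nM

All three numbers come from an ADME assay on MT4 cells (Homo sapiens) for cytotoxicity, read by MTT assay, with a stated time of 4 days; a lower number here means that less compound is tolerated, a higher number that more compound is tolerated. Compound 1 and compound 2 differ only by hydrogen in place of acetyl on a nitrogen on an aromatic ring, and the measured step for this change is a 1.1-fold higher number from compound 1 to compound 2 (0.05 log units; within the scatter). Compound 3 has a different core; the difference between the cores of compound 1 and compound 3 is not broken down here. Compound 4 `COc1c(-c2ccccc2)oc2ccc(N)cc2c1=O` has not yet been measured. It differs from compound 3 by hydrogen in place of acetyl on a nitrogen on an aromatic ring, the same change as between compound 1 and compound 2, at the same kind of place. Because the measured step of a 1.1-fold higher number from compound 1 to compound 2 (0.05 log units; within the scatter) lies within the scatter, for compound 4 the expected step is a 1.1-fold higher number from compound 3 to compound 4 (0.04 log units; within the scatter). Compound 4 is therefore estimated at 220000 nM, with a likely range from 110000 nM to 440000 nM.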

Compound 4, half-maximal cytotoxic concentration: 126000 nM
The estimate for compound 4 lay 1.7-fold (0.24 log units) above the measured number, and the stated range covers the measured number.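

Replacing acetamido with amino on the core of compound 3 gives a 1.6-fold lower number from compound 3 to compound 4 (0.20 log units; within the scatter) in this assay. Set beside the same change on the core of compound 1, the two steps cannot be told apart: the same change on two cores in this assay, a 1.1-fold higher number (0.05 log units; within the scatter) from compound 1 to compound 2 and a 1.6-fold lower number (0.20 log units; within the scatter) from compound 3 to compound 4, 1.8-fold (0.25 log units) apart, within the scatter of two such steps. In these two pairs, then, the change carries across both cores without a step beyond the scatter, but two pairs cannot show that this would hold on other cores in the series, and any real difference smaller than the scatter would go unseen.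

The compounds shown leave open whether a longer acyl chain, such as butanoyl, would behave like acetyl on that nitrogen. The same question stands for a methyl group there.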